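The compounds below may be only part of what the source reports. "The series", "measured", "known", "first", "only" and "open" are said of these compounds alone.

Working notes on the series in a functional assay on PC-3 cells (Homo sapiens) for antiproliferative activity, read by sulforhodamine B assay; on this read-out lower numbers stand for stronger inhibition of growth and higher numbers for weaker inhibition of growth. Compound 3, `O=C(/C=C/c1ccc(O)cc1)c1c(O)cccc1OCC1CCCC1`, gives 3040 nM. Compound 1, `O=C(/C=C/c1ccc(O)cc1)c1c(O)cccc1OCCC1CCCC1`, gives 3480 nM, which differs from compound 3 by a 1.1-fold lower number from compound 1 to compound 3 (0.06 log units; within the scatter). Compound 2, `O=C(/C=C/c1ccc(O)cc1)c1c(O)cccc1OCc1ccccc1`, returns only a limit of the assay, > 30000 nM, as recorded under (the limit of > 30000 nM in this assay, at which 1 of the 3 values shown sits). On the numbers shown, compound 3 sits at the lowest value, with compound 1 so close that the two cannot be told apart.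

The next member, compound 4, `CC(C)CCCOc1cccc(O)c1C(=O)/C=C/c1ccc(O)cc1`, differs from compound 3 thus: isopentyl in place of cyclopentyl on a saturated chain carbon bound to an oxygen on an aromatic ring. Within the data shown here, two measured steps bear on this. The saturated ring change from compound 1 to compound 3 gave a 1.1-fold lower number from compound 1 to compound 3 (0.06 log units; within the scatter), whereas the move to an aromatic group gave an at least 9.8-fold lower number from compound 2 to compound 3 (0.99 log units; beyond the scatter) in the reverse direction. The step to compound 4 keeps a saturated group of the same heavy-atom count and only opens the ring, so a step of the size of the first kind, not the second, is expected: a 1.4-fold higher number from compound 3 to compound 4 (0.14 log units; within the scatter), within the scatter or only a little beyond it. Compound 4 is thus estimated at 4200 nM, in a range from 1500 nM to 12000 nM.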

Compound 4, concentration for 50% growth inhibition: 3600 nM
Beside the measured number, compound 4's estimate is 1.2-fold (0.07 log units) above it; measured number inside the range.
By their numbers in this assay, from the lowest: compounds 3, 1 and 4 (each within the scatter of the next). At a limit, above all of these: compound 2.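

In this assay, the earlier saturated groups all carried a ring. With the ring opened, the step is a 1.2-fold higher number from compound 3 to compound 4 (0.07 log units; within the scatter), and against the longer cyclopentyl-bearing chain it is a 1.0-fold higher number from compound 1 to compound 4 (0.01 log units; within the scatter), so a saturated ring is not required at this position for values of this size. The separation from the aromatic group also holds for an open chain, at an at least 8.3-fold lower number from compound 2 to compound 4 (0.92 log units; beyond the scatter), and this step is only a bound, since compound 2 remains a limit of the assay: the limit of > 30000 nM in this assay, at which 1 of the 4 values shown sits.

Open, from the compounds shown here alone, is whether the saturated groups keep these values with a shorter chain such as ethyl, or with a hydroxyl or an amine at the chain end. Also open, going by these compounds, is whether a cyclohexyl group or a pyridyl ring at this place would follow the saturated groups or compound 2.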